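The source may hold more compounds than are shown below. What is called first, only, known or untested is meant among the compounds shown, and "the series" means these compounds.

Compound 1 `COc1cccc(NC(=O)c2c(O)c3cccnc3n(-c3ccccc3)c2=O)c1` gives 5.7% in a functional assay on the whole organism for inhibition, with Rattus norvegicus as the target, read by paw edema, at a dose of 100 mg/kg by the oral route; on this read-out higher numbers stand for more inhibition at the one dose given (going by the name of the read-out) and lower numbers for less inhibition. Compound 2 `O=C(Nc1cccc(Cl)c1)c1c(O)c2cccnc2n(-c2ccccc2)c1=O` gives 7.6%. Compound 3 `COc1ccccc1NC(=O)c1c(O)c2cccnc2n(-c2ccccc2)c1=O` gives 8.1%.

Compound 3 holds the highest of the three numbers, yet its gaps to compound 2 and to compound 1 both lie within the scatter, so no order among them can be claimed. Compound 4 `O=C(Nc1cccnc1)c1c(O)c2cccnc2n(-c2ccccc2)c1=O` differs from compound 3 by pyridin-3-yl in place of 2-methoxyphenyl on an amide-type nitrogen. The two measured steps that alter the group on the amide-type nitrogen, a number 2.4 percentage points higher from compound 1 to compound 3 (within the scatter) and a number 0.5 percentage points higher from compound 2 to compound 3 (within the scatter), both stayed within the scatter, as did a number 1.9 percentage points higher from compound 1 to compound 2 (within the scatter). Compound 4 is therefore expected to show no step beyond the scatter in this assay, an estimated a number 1.1 percentage points lower from compound 3 to compound 4 (within the scatter). Compound 4 is estimated at 7%, with a range from 0% to 18%.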

Compound 4, a percentage reported as inhibition, in the whole organism at one dose (the size of the read-out at that dose, not a potency): 30.3%
Compound 4: the middle estimate sits 23.3 percentage points below what was measured; the whole stated range lies below it.
By their numbers in this assay, from the lowest: compounds 1, 2 and 3 (each within the scatter of the next); then compound 4.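

On the amide-type nitrogen, pyridin-3-yl gives a number 22.2 percentage points higher from compound 3 to compound 4 (beyond the scatter) and a number 22.7 percentage points higher from compound 2 to compound 4 (beyond the scatter) and also a number 24.6 percentage points higher from compound 1 to compound 4 (beyond the scatter) in this assay while the changes among the three substituted phenyl groups stayed within the scatter. This position therefore does affect the read-out, but the change swaps a carbon-only ring carrying methoxy or chloro for a ring with a hetero atom, and the compounds cannot separate these two differences. Nothing available explains the rise. Still open, on these data alone, is whether unsubstituted phenyl would keep this level, and whether pyridin-2-yl or pyridin-4-yl would match pyridin-3-yl.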